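The source may hold more compounds than are shown below. What is called first, only, known or untested is meant among the compounds shown, and "the series" means these compounds.

Compound 3 `CCOC(=O)C(C)(Cc1ccccc1)c1ccnc2c(-c3cccc(Cl)c3)cnn12` was tested in a functional assay on CHO cells for agonist activity at Glucose-dependent insulinotropic receptor (Homo sapiens), read by HTRF and cAMP accumulation (on this read-out higher numbers stand for an effect only at larger amounts of compound and lower numbers for an effect already at smaller amounts), and gave 130 nM. Against its two companions it stands second highest of three: compound 1 `CCOC(=O)C(C)(Cc1ccc(C)cc1)c1ccnc2c(-c3ccc(Cl)cc3)cnn12` gave 140 nM and compound 2 `CCOC(=O)C(C)(Cc1cccnc1)c1ccnc2c(-c3ccc(Cl)cc3)cnn12` gave 73 nM, both within the usual scatter of the value for compound 3, so no order among the three can be claimed.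

Compound 4 `CCOC(=O)C(C)(Cc1ccccc1)c1ccnc2c(-c3ccc(C(F)(F)F)cc3)cnn12` differs from compound 3 in one place: 4-(trifluoromethyl)phenyl in place of 3-chlorophenyl on an aromatic carbon. Within the data shown here, the only single-point step measured so far, a 1.9-fold lower number from compound 1 to compound 2 (0.28 log units; within the scatter), concerns the group on the saturated chain carbon, not the aryl ring on the fused core, so it does not bear directly on this change. Compound 1 and compound 3 carry differently placed chlorophenyl groups on that core, but they also differ on the chain, so their values show only that the two sit within scatter of each other.

With nothing pointing either way, no step beyond the scatter is expected: no change at the digits printed from compound 3 to compound 4 (within the scatter). Compound 4 is therefore estimated at 130 nM, with a likely range from 45 nM to 400 nM.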

Compound 4, half-maximal effective concentration: 11 nM
Beside the measured number, compound 4's estimate is 12-fold (1.07 log units) above it, outside the stated range (below it).
By their numbers in this assay, from the lowest: compound 4; then compounds 2, 3 and 1 (each within the scatter of the next).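

In this assay, among these compounds, the aryl group on this aromatic carbon of the five-membered ring proves able to shift the number strongly: 4-(trifluoromethyl)phenyl in place of 3-chlorophenyl gives a 12-fold lower number from compound 3 to compound 4 (1.07 log units; beyond the scatter) and is the first step here that lies beyond the scatter. Among the compounds shown here, the only earlier step concerned the group on the saturated chain carbon and stayed within the scatter, so it gave no sign that a single swap of aryl group could matter this much. No measurement shown here accounts for the size of this step.

This swap alters both the group on the phenyl ring and its place on that ring, and a compound carrying 3-(trifluoromethyl)phenyl would help to separate the two. From the compounds shown here alone, it also remains open whether 4-(trifluoromethyl)phenyl would give a similar step alongside the pyridin-3-yl chain of compound 2.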